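Piperazine amides: cytotoxicity on RAW264.7 cells, compound 4 outlook

The source may report more compounds than this note shows. Statements on the series, on what has been measured and on what is new or still open speak of the compounds shown alone.

Measured so far in an ADME assay on RAW264.7 cells (Mus musculus) for cytotoxicity, read by MTT assay, with a stated time of 72 h, tested at 50 ug/mL; a higher number here means more inhibition at the concentration tested (going by the name of the read-out), a lower number less inhibition:
compound 1 `CC(=O)c1ccc(N2CCN(C(=O)c3nc4ccccc4s3)CC2)cc1` gives 62.3%
compound 2 `CC(=O)N1CCN(C(=O)c2nc3cc(C(F)(F)F)ccc3s2)CC1` gives 20.2%
compound 3 `O=C(c1nc2cc(C(F)(F)F)ccc2s1)N1CCN(c2ccncc2)CC1` gives 17.5%

Compound 3 stands as the lowest of the three numbers in this assay, but its nearest neighbour is compound 2, and that gap lies within the scatter; only compound 1 is separated from it beyond the scatter. Within the data shown here, the one single-point step measured so far, a number 2.7 percentage points lower from compound 2 to compound 3 (within the scatter), is itself within the scatter.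

Compound 4 `CC(=O)c1ccc(N2CCN(C(=O)c3nc4cc(C(F)(F)F)ccc4s3)CC2)cc1` differs from compound 3 in one place: 4-acetylphenyl in place of pyridin-4-yl on an amine nitrogen in a ring. Among the measured compounds shown here, no measured step carries this exact change, so the expectation rests on what the values show. Compound 1 carries the same 4-acetylphenyl group on a core without trifluoromethyl and gives 62.3%, whereas both compounds on the trifluoromethyl-bearing core, compound 2 and compound 3, sit low. Which of the two parts of the molecule sets the number cannot be separated from these three values alone, so a step in either direction remains possible.

Compound 4 is therefore expected to land between the two groups, with an estimated step of a number 22.5 percentage points higher from compound 3 to compound 4 (beyond the scatter), giving an expected value of 40% with a range from 15% to 65%.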

Compound 4, a percentage reported as inhibition, at one concentration (the size of the read-out at that concentration, not a potency): 30.6%
Compound 4: the middle estimate sits 9.4 percentage points above what was measured; measured number inside the range.
By their numbers in this assay, from the lowest: compounds 3 and 2 (each within the scatter of the next); then compound 4; then compound 1.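

On the amine nitrogen in the ring, with the trifluoromethyl-bearing core held fixed, 4-acetylphenyl reads higher in this assay than both other groups: the series shows a number 13.1 percentage points higher from compound 3 to compound 4 (beyond the scatter) for the exchange of pyridin-4-yl and a number 10.4 percentage points higher from compound 2 to compound 4 (beyond the scatter) for the exchange of acetyl, and both steps are labelled modest. With 4-acetylphenyl held fixed, the series also now gives a number 31.7 percentage points lower from compound 1 to compound 4 (beyond the scatter) as a single change on the aromatic carbon, a step labelled large, so trifluoromethyl in place of hydrogen and the group on the amine nitrogen each move this number, and the high reading of compound 1 no longer rests on 4-acetylphenyl alone. No data given here bear on why either change shifts the reading.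

Still open is whether trifluoromethyl in place of hydrogen gives a step of similar size with acetyl or pyridin-4-yl on the amine nitrogen, as the compounds shown offer that comparison only for 4-acetylphenyl. Also open, going by these compounds, is how the reading responds to a primary amine or a carboxylic acid in place of the acetyl of 4-acetylphenyl, or to chlorine in place of trifluoromethyl on the aromatic carbon.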